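A few compounds are considered here, and "the series" means these few. Any claim that something is new, unique, unknown or untested is made for them only; others in the source may bear on it.

Measured in a functional assay on DU-145 cells (Homo sapiens) for inhibition, read by trypan blue exclusion, with a stated time of 96 h; on this read-out higher numbers stand for weaker inhibition of growth and lower numbers for stronger inhibition of growth:
- compound 1 `Cc1ccc(C)c(/C=C(/Sc2ccc(Br)cc2)C(=O)c2ccc(Cl)cc2)c1`: 10000 nM
- compound 2 `O=C(/C(=C\c1ccc(F)cc1F)Sc1ccc(Br)cc1)c1ccc(Br)cc1`: 1000 nM
- compound 3 `CN(C)c1ccc(/C=C(/Sc2ccc(Br)cc2)C(=O)c2ccc(Cl)cc2)cc1`: > 100000 nM (a limit, not a number)

For compound 3 the assay gives no number, and > 100000 nM is a limit. Compound 4 `O=C(/C(=C\c1ccc(F)cc1F)Sc1ccc(Br)cc1)c1ccc(Cl)cc1` differs from it in one place: 2,4-difluorophenyl in place of 4-(dimethylamino)phenyl on a double-bonded chain carbon bound to a double-bonded chain carbon. One measured step involves the departing group: an at least 10-fold higher number from compound 1 to compound 3 (1.00 log units; beyond the scatter), with 4-(dimethylamino)phenyl entering in place of 2,5-dimethylphenyl. Compound 2 carries the incoming 2,4-difluorophenyl, and compound 2 gives 1000 nM. Removing the 4-(dimethylamino)phenyl is therefore expected to give a much lower number in this assay, meaning stronger inhibition of growth. The expected size is an at least 100-fold lower number from compound 3 to compound 4 (2.00 log units; beyond the scatter). The estimated value for compound 4 is 1000 nM, with an expected range from 300 nM to 4000 nM.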

Compound 4, concentration for 50% growth inhibition: 1000 nM
Estimate against measurement, compound 4: no gap at the digits printed, within the range that was stated.
By their numbers in this assay, from the lowest: compounds 2 and 4 (each within the scatter of the next); then compound 1. At a limit, above all of these: compound 3.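

In this assay, 2,4-difluorophenyl in place of 4-(dimethylamino)phenyl gives an at least 100-fold lower number from compound 3 to compound 4 (2.00 log units; beyond the scatter), and in place of 2,5-dimethylphenyl it gives a 10-fold lower number from compound 1 to compound 4 (1.00 log units; beyond the scatter), so the group at this place on the chain can shift the result strongly. The first of these steps is only a minimum, as compound 3 stands at a limit and not at a number: the limit of > 100000 nM in this assay, at which 1 of the 4 values shown sits. Chloro in place of bromo on an aromatic carbon, by contrast, gives no change at the digits printed from compound 2 to compound 4 (within the scatter). The compounds shown leave open how an unsubstituted phenyl or a morpholine at this place would read.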